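Extending the sulfonyl chain in a prostaglandin D2 receptor series

The source may report more compounds than this note shows. Statements on the series, on what has been measured and on what is new or still open speak of the compounds shown alone.

Measured compounds:
- compound 1, `CN(C)S(=O)(=O)c1cncc(C#Cc2cc(Cl)ccc2OCC(=O)O)c1`: 37 nM
- compound 2, `CCS(=O)(=O)c1ccc(C)c(C#Cc2cc(Cl)ccc2OCC(=O)O)c1`: 8.6 nM

Both measured compounds share a common core carrying a chloro substituent and an acid-bearing side chain, joined through an alkyne to a second aromatic ring that bears a sulfonyl group. In an assay on CHO cells for displacement of a labelled ligand from prostaglandin D2 receptor 2 (Homo sapiens), read by scintillation counting (a higher number here means a weaker inhibitor, a lower number a stronger inhibitor), compound 1 gives 37 nM, and in the same assay compound 2 gives 8.6 nM. Compound 2 thus has the lower of the two numbers, and the gap to compound 1 is large enough to count as a real difference rather than measurement noise.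

Compound 3, `Cc1ccc(S(=O)(=O)CC(C)C)cc1C#Cc1cc(Cl)ccc1OCC(=O)O`, has not yet been measured. It differs from compound 2 in one place: isopropyl in place of methyl on a saturated chain carbon bound to a sulfonyl sulfur. Among the compounds with values here, no measured pair in this set changes only this chain, so there is no direct precedent for the size of the effect. The expectation, resting on the strong result of compound 2 at 8.6 nM, is that the longer chain is tolerated and that the step of a 1.4-fold higher number from compound 2 to compound 3 (0.14 log units; within the scatter) stays within the usual scatter, leaning slightly toward a weaker result. Compound 3 is therefore estimated at 12 nM, with a plausible range from 4 nM to 40 nM.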

Compound 3, inhibition constant: 3 nM
For compound 3 the middle estimate is 4.0-fold (0.60 log units) above the measured one; measured number outside the range, below it.
By their numbers in this assay, from the lowest: compound 3; then compound 2; then compound 1.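

In this assay, going from ethylsulfonyl to isobutylsulfonyl gives a 2.9-fold lower number from compound 2 to compound 3 (0.46 log units; beyond the scatter), so the larger chain is more than tolerated: the number drops by a real margin. This is the only pair shown that changes the chain alone, and it establishes that the group on the saturated chain carbon bound to a sulfonyl sulfur affects the reading, with isopropyl in place of methyl giving the stronger inhibitor of the two. Nothing available beyond these binding numbers bears on why the number falls.

On these data alone, one step gives a direction for a single change, not a trend, so it remains open whether the numbers keep falling with a longer chain such as hexyl, or with a cyclohexyl ring on the same carbon. Also open, as far as these compounds go, is whether an amine or a carboxylic acid on this chain would keep the number low, and whether the same extension would have a similar effect on a compound with the core of compound 1.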